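Bromophenyl ketones with a benzylsulfanyl enone and a fluorophenyl swap

A few compounds are considered here, and "the series" means these few. Any claim that something is new, unique, unknown or untested is made for them only; others in the source may bear on it.

The study concerns three measured compounds and one still to be measured. Compound 1 `CSc1ccc(/C=C(/SCc2ccc(C)cc2)C(=O)c2ccc(Br)cc2)cc1` was tested in a functional assay on DU-145 cells (Homo sapiens) for inhibition, read by trypan blue exclusion, with a stated time of 96 h; a lower number here means a stronger inhibitor of growth, a higher number a weaker inhibitor of growth. Compound 1 gives only a limit there, > 100000 nM, a value at the limit of > 100000 nM in this assay, at which 1 of the 3 values shown sits. Compound 2 `CSc1ccc(/C=C(/SCc2ccc(Br)cc2)C(=O)c2ccc(C(=O)O)cc2)cc1` gives 10000 nM in this assay, and compound 3 `O=C(O)c1ccc(C(=O)/C(=C\c2ccccc2F)SCc2ccc(Br)cc2)cc1` gives 10000 nM. Between them lies one change, (2-fluorophenyl in place of 4-(methylsulfanyl)phenyl on a double-bonded chain carbon bound to a double-bonded chain carbon), and the step of no change at the digits printed from compound 2 to compound 3 (within the scatter). How the core of compound 1 differs from that of compound 2 is not broken down here. Compound 4 `Cc1ccc(CS/C(=C/c2ccccc2F)C(=O)c2ccc(Br)cc2)cc1` differs from compound 1 by 2-fluorophenyl in place of 4-(methylsulfanyl)phenyl on a double-bonded chain carbon bound to a double-bonded chain carbon, the same change. In this assay the step from compound 1 to compound 4 is expected to be a step that the limit leaves unreadable from compound 1 to compound 4, resting on the unchanged step seen in no change at the digits printed from compound 2 to compound 3 (within the scatter), so compound 4 is expected to sit near 150000 nM, likely again as a limit.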

Compound 4, concentration for 50% growth inhibition: 10000 nM
The estimate for compound 4 lay 15-fold (1.18 log units) above the measured number, and the stated range ends above it.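

In this assay the swap to 2-fluorophenyl from 4-(methylsulfanyl)phenyl gives an at least 10-fold lower number from compound 1 to compound 4 (1.00 log units; beyond the scatter). Set beside the earlier step, the change does not carry unaltered from one core to the other in this series: the same change on two cores in this assay, no change at the digits printed (within the scatter) from compound 2 to compound 3 and an at least 10-fold lower number (1.00 log units; beyond the scatter) from compound 1 to compound 4, at least 10-fold (1.00 log units) apart, beyond the scatter of two such steps

Compound 1 gives only a limit, > 100000 nM, so the full size of its step is not known, and the result does not show which difference between the two cores decides the outcome.

The compounds shown leave open whether any single difference between the cores accounts for this gap. Also open, going by these compounds, is how the same swap would read on a core carrying an amine.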